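The source may report more compounds than this note shows. Statements on the series, on what has been measured and on what is new or still open speak of the compounds shown alone.

In a functional assay on liver (Sus scrofa) for inhibition of squalene monooxygenase (Homo sapiens), using microsomes (a higher number here means a weaker inhibitor, a lower number a stronger inhibitor), compound 3 `CCN(C/C=C/C#CC(C)(C)C)Cc1cccc(OC[Si](C)(C)c2ccc(O)cc2)c1` gives 8000 nM, the highest number of the three measured compounds. Compound 1 `CCN(C/C=C/C#CC(C)(C)C)Cc1cccc(OC[Si](C)(C)c2ccc(F)cc2)c1` gives 60 nM in this assay, and compound 2 `CCN(C/C=C/C#CC(C)(C)C)Cc1cccc(OC[Si](C)(C)c2cccc(C)c2)c1` gives 3000 nM. The measured steps are a 50-fold higher number from compound 1 to compound 2 (1.70 log units; beyond the scatter), a 130-fold higher number from compound 1 to compound 3 (2.12 log units; beyond the scatter) and a 2.7-fold higher number from compound 2 to compound 3 (0.43 log units; beyond the scatter), so the group on the phenyl on silicon moves the number across a wide span, and compound 3 sits at its weak end.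

Compound 4 `CCN(C/C=C/C#CC(C)(C)C)Cc1cccc(OC[Si](C)(C)c2ccc(C=O)cc2)c1` differs from compound 3 by formyl in place of hydroxy on an aromatic carbon. Among the compounds with values here, no measured step exchanges hydroxy for formyl, so the only guidance is indirect: the steps of a 130-fold higher number from compound 1 to compound 3 (2.12 log units; beyond the scatter) and a 2.7-fold higher number from compound 2 to compound 3 (0.43 log units; beyond the scatter) both leave the hydroxy compound weakest, which suggests that leaving the hydroxy behind is more likely to lower the number than to raise it, though the size of such a move is not set by any pair here. Compound 4 is therefore expected to show a modest step of a 2.7-fold lower number from compound 3 to compound 4 (0.43 log units; beyond the scatter), estimated at 3000 nM with a range from 600 nM to 15000 nM.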

Compound 4, half-maximal inhibitory concentration: 100 nM
Compound 4: the middle estimate sits 30-fold (1.48 log units) above what was measured; the whole stated range lies above it.
By their numbers in this assay, from the lowest: compounds 1 and 4 (each within the scatter of the next); then compound 2; then compound 3.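

In this assay the change from hydroxy to formyl, para to a large group, gives an 80-fold lower number from compound 3 to compound 4 (1.90 log units; beyond the scatter), so the weak end of the series belongs to the hydroxy compound and not to every group placed here. The steps of a 30-fold lower number from compound 2 to compound 4 (1.48 log units; beyond the scatter) and a 1.7-fold higher number from compound 1 to compound 4 (0.22 log units; within the scatter) set the formyl compound well apart from compound 2 but leave formyl and fluoro indistinguishable at this place, so the two groups serve equally well in this assay, with hydroxy going against them. Nothing available accounts for why the exchange acts so strongly.

As far as these compounds go, what a methoxy group, an amine or a carboxylic acid would give at this place remains open. Also open is whether compound 2 owes its number to the methyl group itself or to where it sits, as a 4-methylphenyl on silicon is not among these compounds.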